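Swapping the Thiophene Acid for a Methylpyrazole

The source may report more compounds than this note shows. Statements on the series, on what has been measured and on what is new or still open speak of the compounds shown alone.

Of the compounds shown here, two have so far been tested in an assay on isolated protein for activation of cGMP-dependent protein kinase 1 (Homo sapiens), read by ADP-Glo, with stated times of 120 min and 40 min; on this read-out lower numbers stand for an effect already at smaller amounts and higher numbers for an effect only at larger amounts of compound. Compound 1 `O=C(O)c1ccc(CN2CCC[C@H](OCc3cc(Cl)cc(Cl)c3)[C@@H]2c2ccccc2)s1` gives 76000 nM in this assay, the lowest of the two numbers. Compound 2 `OC[C@@H](O[C@H]1CCCN(Cc2ccc(-c3nn[nH]n3)cc2)[C@H]1c1ccccc1)c1cc(Cl)cc(Cl)c1` gives 131000 nM in this assay, which lies within the usual scatter of compound 1, so the two cannot be told apart on these numbers. Among the compounds with values here, both sit at the weak end of the scale, and no pair of measured compounds differs in only one place, so no measured step is available to lean on.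

Compound 3 `Cn1cc(CN2CCC[C@H](OCc3cc(Cl)cc(Cl)c3)[C@@H]2c2ccccc2)cn1` has not yet been measured in this assay. It arises from compound 1 by a single change: 1-methyl-1H-pyrazol-4-yl in place of 5-carboxythiophen-2-yl on a saturated chain carbon bound to an amine nitrogen in a ring. Neither measured compound carries a 1-methyl-1H-pyrazol-4-yl group, so nothing here shows what this exchange does. The expectation is that the step from compound 1 to compound 3 is roughly a 1.4-fold higher number from compound 1 to compound 3 (0.16 log units; within the scatter), likely within the scatter, with a modest lean toward a higher number. On that basis compound 3 is estimated at 110000 nM, with a range from 30000 nM to 400000 nM.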

Compound 3, half-maximal effective concentration: 110000 nM
The estimate for compound 3 equals the measured number at the digits printed; measured number inside the range.
By their numbers in this assay, from the lowest: compounds 1, 3 and 2 (each within the scatter of the next).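

Within the data shown here, this is the first measured step that changes one place only: in this assay, moving from 5-carboxythiophen-2-yl to 1-methyl-1H-pyrazol-4-yl on a saturated chain carbon bound to an amine nitrogen in a ring gives a 1.4-fold higher number from compound 1 to compound 3 (0.16 log units; within the scatter) and so stays within the scatter. The exchange replaces the whole acid-bearing group, removing the carboxylic acid and its one hydrogen-bond donor, yet these two numbers cannot be told apart, so for this pair the acid-bearing group shows no measurable advantage over the methylpyrazole on this weak part of the scale. Nothing available explains why the two groups read alike.

On these data alone, whether any group at this place can move the number beyond the scatter remains open, since a single pair at the weak end of the scale says little about the position as a whole. A primary amide or a pyridine ring in the same place could test this, and so could a longer chain between the amine nitrogen and the five-membered ring.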